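The source may report more compounds than this note shows. Statements on the series, on what has been measured and on what is new or still open speak of the compounds shown alone.

Measured so far:
compound 1 `COc1ccc(/C=C/C(=O)c2ccc(OC)c(OC)c2)cc1O` — 73.5%
compound 2 `COc1ccc(CCCc2cccc(OC)c2OC)c(O)c1` — 63%

Both numbers come from an ADME assay on RAW264.7 cells (Mus musculus) for cytotoxicity, read by MTT assay, with a stated time of 24 h, tested at 10 ug/mL; a lower number here means a stronger effect, a higher number a weaker effect of the compound at the concentration tested. Compound 1 gives 73.5% there, the higher of the two readings. Compound 2 gives 63%, lower by more than the usual scatter. Among the measured compounds shown here, no single-point change links compound 2 to compound 1, so the pair shows only that the two values sit apart.

Compound 3 `COc1ccc(/C=C/C(=O)c2ccc(OC)c(OC)c2)cc1OC` is the unmeasured analogue of compound 1. The change is methyl in place of hydrogen on an oxygen on an aromatic ring: the hydroxy of compound 1 becomes a methoxy. For the measured compounds named here, no measured pair shows this change in this assay, so there is nothing to scale the step by. The expectation is a small step, if any, within the usual scatter, with no clear direction. Compound 3 is expected at 70%, between 55% and 85%. The expected step is a number 3.5 percentage points lower from compound 1 to compound 3 (within the scatter).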

Compound 3, a percentage reported as activity, at one concentration (the size of the read-out at that concentration, not a potency): 60.4%
For compound 3 the middle estimate is 9.6 percentage points above the measured one; low and high end bracket the measured number.
By their numbers in this assay, from the lowest: compounds 3 and 2 (each within the scatter of the next); then compound 1.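

Methyl in place of hydrogen on this oxygen gives the series its first single-point step: in this assay, hydroxy to methoxy reads a number 13.1 percentage points lower from compound 1 to compound 3 (beyond the scatter). The hydroxy position of compound 1 is therefore not silent in this read-out, and the change moves the reading towards the stronger effect at the concentration tested. This rests on one pair alone, and no evidence on the cause of the step is at hand.

From the compounds shown here alone, whether an ethoxy group or a longer chain on the same oxygen would extend this step remains open, as does the outcome with an amine in place of the hydroxy. Also open, going by these compounds, is whether the same methyl on the hydroxy of compound 2 would give a step of similar size.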